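The source may report more compounds than this note shows. Statements on the series, on what has been measured and on what is new or still open speak of the compounds shown alone.

Measured compounds:
compound 1, `C=C(Br)C(=O)Nc1cccc(-c2cn3nc(Cc4ccc(Cl)cc4)sc3n2)c1`, 1100 nM
compound 2, `Nc1cccc(-c2cn3nc(Cc4ccc(Cl)cc4)sc3n2)c1`, 6000 nM
compound 3, `Nc1cccc(-c2cn3c(-c4ccccc4)csc3n2)c1`, 34000 nM

The three compounds were tested in a functional assay on FM3A cells (Mus musculus) for inhibition, read by cell counting, with a stated time of 2 days; on this read-out lower numbers stand for stronger inhibition and higher numbers for weaker inhibition. Compound 2 gives 6000 nM, and compound 1, which carries the acylated amine, gives 1100 nM. The step between them, a 5.5-fold lower number from compound 2 to compound 1 (0.74 log units; beyond the scatter), is the change ((1-bromoethenyl)carbonyl in place of hydrogen on a nitrogen on an aromatic ring). Compound 3 has a different core; how the cores of compound 2 and compound 3 differ is not broken down here. In this assay compound 3 gives 34000 nM, the highest of the three numbers.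

Compound 4, `C=C(Br)C(=O)Nc1cccc(-c2cn3c(-c4ccccc4)csc3n2)c1`, has not yet been measured in this assay. It stands to compound 3 as compound 1 stands to compound 2: the change (1-bromoethenyl)carbonyl in place of hydrogen on a nitrogen on an aromatic ring is the same change, made at the same place, on the core of compound 3 instead of the core of compound 2. Because the earlier step of a 5.5-fold lower number from compound 2 to compound 1 (0.74 log units; beyond the scatter) lowered the number, a step of about the same size, a 5.7-fold lower number from compound 3 to compound 4 (0.75 log units; beyond the scatter), is expected here. Compound 4 is therefore estimated at 6000 nM, with a likely range from 2500 nM to 15000 nM.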

Compound 4, half-maximal inhibitory concentration: 1300 nM
Beside the measured number, compound 4's estimate is 4.6-fold (0.66 log units) above it; measured number outside the range, below it.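

In this assay, the (1-bromoethenyl)carbonyl group in place of hydrogen on the nitrogen lowers the number on both cores, and on the core of compound 3 the step is a 26-fold lower number from compound 3 to compound 4 (1.42 log units; beyond the scatter). The direction of the change therefore carries from one core to the other in these two pairs, but its size does not: the same change on two cores in this assay, a 5.5-fold lower number (0.74 log units; beyond the scatter) from compound 2 to compound 1 and a 26-fold lower number (1.42 log units; beyond the scatter) from compound 3 to compound 4, 4.8-fold (0.68 log units) apart, beyond the scatter of two such steps These two pairs show only that the size of the step depends on the core it is made on; they do not say which part of the core sets that size, why it does so, or what the step would be on a third core.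

The compounds shown leave open whether the bromine or the double bond is needed for the step, a question that a plain acetyl or a propanoyl group on the same nitrogen of both cores could answer. As far as these compounds go, it also remains open whether the gap between the two steps would persist with a longer chain or a carboxylic acid on either core.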